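The source may report more compounds than this note shows. Statements on the series, on what has been measured and on what is new or still open speak of the compounds shown alone.

Measured so far, in a functional assay on the whole organism (strain Jcl:Sprague-Dawley) for inhibition, with Rattus norvegicus as the target, with stated times of 3 min and 3 h, at a dose of 1 mg/kg by the intravenous route; a higher number here means more inhibition at the dose given (going by the name of the read-out), a lower number less inhibition:
compound 1 `CNCc1cn(S(=O)(=O)c2ccc(OC)cn2)c(-c2cccnc2F)c1F` — 95%
compound 2 `CNCc1cn(S(=O)(=O)c2cccc(C)n2)c(-c2cccnc2F)c1F` — 91%
compound 3 `CNCc1cn(S(=O)(=O)c2cccnc2Cl)c(-c2cccnc2F)c1F` — "not determined" (no result reported)

Going by the values given here, the one measured step, a number 4 percentage points lower from compound 1 to compound 2 (within the scatter), concerns an exchange of the group on the sulfonyl sulfur and lies within the scatter. Compound 3 stands nowhere on the numbers: no inhibition was reported for it. Compound 4 `CNCc1cn(S(=O)(=O)c2cncc(C)c2)c(-c2cccnc2F)c1F` differs from compound 3 by 5-methylpyridin-3-yl in place of 2-chloropyridin-3-yl on a sulfonyl sulfur. Among the compounds with values here, no measured step bears on this particular change, so no direction can be read from it. What the series shows is that compound 1 with 95% and compound 2 with 91% both give high inhibition with differing groups on the sulfonyl sulfur, and no step beyond the scatter has appeared. For compound 4 the inhibition in this assay is expected to be about 85%, estimated within 60% to 98%.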

Compound 4, a percentage reported as inhibition, in the whole organism at one dose (the size of the read-out at that dose, not a potency): 87%
Estimate against measurement, compound 4: 2 percentage points below; the range from low to high includes it.
By their numbers in this assay, from the lowest: compounds 4, 2 and 1 (each within the scatter of the next).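

In this assay, a pyridin-3-yl group on the sulfonyl sulfur, here 5-methylpyridin-3-yl, joins the two pyridin-2-yl groups with a number 4 percentage points lower from compound 2 to compound 4 (within the scatter) and a number 8 percentage points lower from compound 1 to compound 4 (within the scatter). High inhibition at this position therefore does not depend on which of these pyridine attachments is present, at this single dose. No data on hand explain this result.

The exchange of 2-chloropyridin-3-yl for 5-methylpyridin-3-yl cannot be read, as compound 3 has no result. Also open, from the compounds shown here alone, is whether a carboxylic acid on the pyridine ring, or a plain butyl chain in its place, would keep this inhibition.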